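Swapping the chain stereocentre from compound 2 to compound 4

The source may hold more compounds than are shown below. What is called first, only, known or untested is meant among the compounds shown, and "the series" means these compounds.

Three measured compounds share one core and carry a nitrooxy group on a chain joined through an ester. Compound 1 `CC1=C(C(=O)OCCO[N+](=O)[O-])C(c2cccc3nonc23)C([N+](=O)[O-])=C(C)C1` gives 31100 nM in a functional assay (cardiac atrium) for agonist activity, with Cavia porcellus as the target; on this read-out lower numbers stand for an effect already at smaller amounts and higher numbers for an effect only at larger amounts of compound. Compound 3 `CC1=C(C(=O)OCCCCO[N+](=O)[O-])C(c2cccc3nonc23)C([N+](=O)[O-])=C(C)C1` gives 4030 nM in this assay, and the change between them is a 7.7-fold lower number from compound 1 to compound 3 (0.89 log units; beyond the scatter). Compound 2 `CC1=C(C(=O)O[C@H](C)CO[N+](=O)[O-])[C@H](c2cccc3nonc23)C([N+](=O)[O-])=C(C)C1` gives 1920 nM, the lowest of the three numbers; compound 3 stands nearest to it and compound 1 furthest, both gaps beyond the scatter.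

Compound 4 `CC1=C(C(=O)O[C@@H](C)CO[N+](=O)[O-])[C@H](c2cccc3nonc23)C([N+](=O)[O-])=C(C)C1` differs from compound 2 in a single respect: the two compounds have the same atoms and bonds and differ only in configuration as drawn: 1 of 2 stereo elements differ; a stereocentre at a saturated chain carbon is drawn R in compound 2 and S in compound 4. Within the data shown here, no measured step bears on such a change. Among the measured compounds shown here, the one step available alters the chain between the ester oxygen and the nitrooxy group and says nothing about configuration, so the size and direction of the effect of a change in configuration at this carbon cannot be read from the data. Mirror-image pairs often differ in this assay, but the data give no size for that. With that uncertainty, compound 4 is expected to give 3500 nM, with a range from 900 nM to 14000 nM. Expressed as a step, this estimate means a 1.8-fold higher number from compound 2 to compound 4 (0.26 log units; within the scatter).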

Compound 4, half-maximal effective concentration: 156 nM
Compound 4: the middle estimate sits 22-fold (1.35 log units) above what was measured; the measured number lies below the stated range.
By their numbers in this assay, from the lowest: compound 4; then compound 2; then compound 3; then compound 1.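

In this assay, inverting a single stereocentre at a saturated chain carbon, from R to S, gives a 12-fold lower number from compound 2 to compound 4 (1.09 log units; beyond the scatter), and compound 4 has the lowest number of the four compounds. The earlier step, a 7.7-fold lower number from compound 1 to compound 3 (0.89 log units; beyond the scatter), involved a change in the chain itself, so it could show only that the chain between the ester oxygen and the nitrooxy group matters; this new step shows that the spatial arrangement at one chain carbon also matters, even with no atom or bond altered. The shift can be assigned to that one carbon alone, because nothing else separates the pair: the fact that compounds 2 and 4 differ only in the configuration as drawn.

As far as these compounds go, the second stereo element is drawn the same way in compound 2 and compound 4, so its contribution remains unknown. The data do not explain the lower number with the S arrangement. From the compounds shown here alone, it also remains open whether the same preference would hold with an ethyl group on this chain carbon, or with a carboxylic acid in place of the nitrooxy group.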